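A few compounds are considered here, and "the series" means these few. Any claim that something is new, unique, unknown or untested is made for them only; others in the source may bear on it.

In a functional assay on T-24 cells (Homo sapiens) for antiproliferative activity, read by MTT assay, with a stated time of 48 h (on this read-out higher numbers stand for weaker inhibition and lower numbers for stronger inhibition), compound 1 `COc1ccccc1NC(=O)Nc1cccc(CNc2nccnc2Cl)c1` gives 10400 nM. Compound 2 `O=C(Nc1cccc(CNc2nccnc2Cl)c1)NC1CCCC1` stands only at a limit of the assay, > 40000 nM. Compound 3 `O=C(Nc1cccc(CNc2nccnc2Cl)c1)NC1CCCCC1` also stands only at a limit, > 40000 nM. Compound 4 `Cc1ccc(NC(=O)Nc2cccc(CNc3nccnc3Cl)c2)cc1Cl` differs from it as follows: 3-chloro-4-methylphenyl in place of cyclohexyl on an amide-type nitrogen. Thus 3-chloro-4-methylphenyl takes the place of cyclohexyl on an amide-type nitrogen. For the measured compounds named here, two measured steps bear on this, an at least 3.8-fold higher number from compound 1 to compound 3 (0.58 log units; beyond the scatter) and an at least 3.8-fold higher number from compound 1 to compound 2 (0.58 log units; beyond the scatter). Both lie beyond the scatter, and both lead away from the aromatic 2-methoxyphenyl. Read backwards, they suggest a lower number and stronger inhibition with an aromatic ring there, although compound 1 is the only measured case. The expected change is an at least 3.6-fold lower number from compound 3 to compound 4 (0.56 log units; beyond the scatter). For compound 4 the estimated value is 11000 nM, within an expected range of 3500 nM to 35000 nM.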

Compound 4, half-maximal inhibitory concentration: 7390 nM
The estimate for compound 4 lay 1.5-fold (0.17 log units) above the measured number; measured number inside the range.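

In this assay, a second aromatic group now backs what compound 1 alone suggested, giving an at least 5.4-fold lower number from compound 3 to compound 4 (0.73 log units; beyond the scatter) and an at least 5.4-fold lower number from compound 2 to compound 4 (0.73 log units; beyond the scatter). Those sizes are only minimums, because compound 2 and compound 3 each stand at a limit rather than at a number: the limit of > 40000 nM in this assay, at which 2 of the 4 values shown sit. Between the two aromatic groups the change is a 1.4-fold lower number from compound 1 to compound 4 (0.15 log units; within the scatter), so 3-chloro-4-methylphenyl and 2-methoxyphenyl cannot be told apart here.

Still open, as far as these compounds go, is whether the ring must contain only carbon, as a pyridyl ring would test. Also open, from the compounds shown here alone, is whether a benzyl group, with one carbon set before the ring, would serve as well.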